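This account rests on a few compounds, and the source may have more. Where it says the series, first, only, none or still open, it means among the compounds named here.

Measured so far in a functional assay on HT-29 cells (Homo sapiens) for cytotoxicity, read by MTT assay, with a stated time of 72 h; on this read-out higher numbers stand for weaker inhibition of growth and lower numbers for stronger inhibition of growth:
- compound 1, `CCCCCSc1nc(NCc2ccc([Se]C)cc2)c2ccccc2n1`, gives 14400 nM
- compound 2, `CSc1nc(NCc2ccc([Se]C)cc2)c2ccccc2n1`, gives only a limit of the assay, > 100000 nM
- compound 3, `CCCCC[Se]c1nc(N)c2cccnc2n1`, gives 5910 nM

Compound 1 and compound 2 share one core and differ in a single place: hydrogen in place of butyl on a saturated chain carbon bound to a sulfur. On this change the number rises, an at least 6.9-fold higher number from compound 1 to compound 2 (0.84 log units; beyond the scatter); the size of that step is bounded only from below, since the value of compound 2 is a limit, (the limit of > 100000 nM in this assay, at which 1 of the 3 values shown sits). Compound 3 carries a different core; the difference between the core of compound 3 and the core of compound 1 is not broken down here. Of the two numbers given, that of compound 3 is the lower, and its gap to compound 1 lies beyond the usual scatter.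

Compound 4, `C[Se]c1nc(N)c2cccnc2n1`, is not yet measured. It differs from compound 3 by hydrogen in place of butyl on a saturated chain carbon bound to a selenium atom. Among the measured compounds shown here, this is the same kind of change as the one from compound 1 to compound 2, not the same: there the place is a saturated chain carbon bound to a sulfur, here a saturated chain carbon bound to a selenium atom. For compound 4 the expected step is an 8.5-fold higher number from compound 3 to compound 4 (0.93 log units; beyond the scatter), an estimate that rests on the measured step of an at least 6.9-fold higher number from compound 1 to compound 2 (0.84 log units; beyond the scatter). Because the earlier step ends at the limit of > 100000 nM in this assay, at which 1 of the 3 values shown sits, only its lower bound is known, so the estimate for compound 4 is wide and may itself land at a limit. Compound 4 is expected to give about 50000 nM, between 15000 nM and 200000 nM.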

Compound 4, concentration for 50% growth inhibition: 44100 nM
For compound 4 the middle estimate is 1.1-fold (0.05 log units) above the measured one, and the stated range covers the measured number.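

In this assay, hydrogen in place of butyl on a saturated chain carbon bound to a selenium atom gives a 7.5-fold higher number from compound 3 to compound 4 (0.87 log units; beyond the scatter), so going from pentyl to methyl weakens growth inhibition on this core too. Set beside the same change on the core of compound 1, where the chain carbon is bound to a sulfur, the step runs in the same direction on both cores, and no difference in its size can be claimed: the same change on two cores in this assay, an at least 6.9-fold higher number (0.84 log units; beyond the scatter) from compound 1 to compound 2 and a 7.5-fold higher number (0.87 log units; beyond the scatter) from compound 3 to compound 4; the limit leaves it open whether they differ. The value of compound 2 is a limit, so these two pairs show a shared direction and not a fixed step size that carries from core to core, and they also differ in whether sulfur or selenium holds the chain: the limit of > 100000 nM in this assay, at which 1 of the 4 values shown sits.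

The compounds shown leave open how intermediate chains such as ethyl or propyl, or a chain longer than pentyl, would behave on either core, and thus whether the response to chain length is gradual or abrupt. They also leave open what an amine or a carboxylic acid carried on the chain would do, and whether sulfur and selenium give different values when all else on a core is the same.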